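Swapping a pyrazolyl for an imidazolyl on the shared core

The compounds below may be only part of what the source reports. "The series", "measured", "known", "first", "only" and "open" are said of these compounds alone.

compound 1 `c1ccc(-c2nc[nH]n2)c(NCC2=NCCN2)c1`: 5.01 nM
compound 2 `Cn1ccc(-c2ccccc2NCC2=NCCN2)n1`: 50.1 nM
compound 3 `CCn1ccc(-c2ccccc2NCC2=NCCN2)n1`: a limit, < 100000 nM

In an in vitro functional assay on cells (Fibroblast) for agonist activity at Alpha-1B adrenergic receptor (Homo sapiens) (a higher number here means that more compound is needed for the effect, a lower number that less compound is needed), compound 1 gives 5.01 nM. Compound 2 gives 50.1 nM, the highest of the two readable numbers. For compound 3 the assay reports only a limit, < 100000 nM. Compound 4 `Cn1ccnc1-c1ccccc1NCC1=NCCN1` is not yet measured; it differs from compound 2 by 1-methyl-1H-imidazol-2-yl in place of 1-methyl-1H-pyrazol-3-yl on an aromatic carbon. Among the measured compounds shown here, the one readable step that changed the group on this aromatic carbon, a 10-fold higher number from compound 1 to compound 2 (1.00 log units; beyond the scatter), was modest. The step that the limit leaves unreadable from compound 2 to compound 3 cannot be read. Another change of the five-membered aromatic ring on this carbon is therefore expected to shift the number by a modest amount, in either direction, so compound 4 is estimated at 30 nM, with a range from 5 nM to 300 nM, which means a 1.7-fold lower number from compound 2 to compound 4 (0.22 log units; within the scatter).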

Compound 4, half-maximal effective concentration: 39.8 nM
For compound 4 the middle estimate is 1.3-fold (0.12 log units) below the measured one; the range from low to high includes it.
By their numbers in this assay, from the lowest: compound 1; then compounds 4 and 2 (each within the scatter of the next).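

In this assay, exchanging 1-methyl-1H-pyrazol-3-yl for 1-methyl-1H-imidazol-2-yl, two rings with the same atoms joined differently, gives a 1.3-fold lower number from compound 2 to compound 4 (0.10 log units; within the scatter). At this aromatic carbon, then, rearranging the ring atoms in this way leaves the number within the scatter, whereas the step away from 1H-1,2,4-triazol-3-yl is readable: a 7.9-fold higher number from compound 1 to compound 4 (0.90 log units; beyond the scatter). The data shown give no reason for that gap.

Still open, from the compounds shown here alone, is how the number would respond to 1H-imidazol-2-yl without its methyl. Also open, going by these compounds, is the effect of an amine on the five-membered ring.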